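A Larger Group on the Carbonyl Carbon of Compound 2

This account rests on a few compounds, and the source may have more. Where it says the series, first, only, none or still open, it means among the compounds named here.

In a physicochemical assay for solubility, read by HPLC, at pH 6.8 (a higher number here means a more soluble compound, a lower number a less soluble compound), compound 1 (`Cc1cc(-c2nc3cccnn3c2-c2ccnc(NC(=O)c3cccnc3)c2)ccc1F`) gives 0.92 ug/mL and compound 2 (`Cc1cc(-c2nc3cccnn3c2-c2ccnc(NC(=O)c3ccncc3)c2)ccc1F`) gives 0.75 ug/mL within the scatter of each other. Among the compounds with values here, the change to compound 3 (`Cc1cc(-c2nc3cccnn3c2-c2ccnc(NC(=O)c3ccc(C)[n+]([O-])c3)c2)ccc1F`) is a group of 8 heavy atoms (6 carbon, 1 nitrogen, 1 oxygen; one six-membered aromatic ring with 1 hetero atom) in place of a group of 6 heavy atoms (5 carbon, 1 nitrogen; one six-membered aromatic ring with 1 hetero atom), on a carbonyl carbon and no measured step is of this kind. Within the data shown here, the only measured step is a 1.2-fold lower number from compound 1 to compound 2 (0.09 log units; within the scatter) and it concerns pyridin-3-yl and pyridin-4-yl alone, so it offers little guidance. The expected step is a 2.0-fold higher number from compound 2 to compound 3 (0.30 log units; within the scatter) and it is only loosely estimated. Compound 3 is estimated at 1.5 ug/mL with an expected range from 0.5 ug/mL to 6 ug/mL in this assay once measured.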

Compound 3, solubility: 2.4 ug/mL
For compound 3 the middle estimate is 1.6-fold (0.20 log units) below the measured one; measured number inside the range.
By their numbers in this assay, from the lowest: compounds 2 and 1 (each within the scatter of the next); then compound 3.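

In this assay, within the data shown here, the group of 8 heavy atoms on the carbonyl carbon gives the first step at this position that lies beyond the scatter, with a 3.2-fold higher number from compound 2 to compound 3 (0.51 log units; beyond the scatter) and with a 2.6-fold higher number from compound 1 to compound 3 (0.42 log units; beyond the scatter). The position therefore responds to a change of group, which the two pyridinyl groups alone had not shown. No evidence is available on what lies behind this step.

On these data alone, the methyl group and the oxygen enter together, so their separate shares remain open. As far as these compounds go, a methylpyridinyl group without the oxygen could separate them, and an amine or a carboxylic acid on this ring remains untested here.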